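The compounds below may be only part of what the source reports. "The series", "measured", "known", "first", "only" and "open" are said of these compounds alone.

Compound 1, whose structure is `Cc1cccn2cc(-c3nnc(-c4ccc(Br)cc4)o3)nc12`, was tested in a functional assay on PC-3 cells (Homo sapiens) for antiproliferative activity, read by MTT assay, with a stated time of 48 h (a lower number here means a stronger inhibitor, a higher number a weaker inhibitor), where compound 1 gives 37800 nM. Compound 2, with the structure `Cc1cccn2cc(-c3nnc(-c4ccc(N(C)C)cc4)o3)nc12`, carries the change dimethylamino in place of bromo on an aromatic carbon relative to compound 1, and in this assay compound 2 gives 11600 nM. That single exchange produced a 3.3-fold lower number from compound 1 to compound 2 (0.51 log units; beyond the scatter), a modest gain that nonetheless stands outside the scatter of repeated runs.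

Compound 3, with the structure `Cc1cc(Br)c2nc(-c3nnc(-c4ccc(Br)cc4)o3)cn2c1`, rests on a different core; how the core of compound 3 differs from the core of compound 1 is not broken down here. In this assay compound 3 gives 24500 nM, a number that sits within the scatter of compound 1 and so cannot be ranked against it.

Compound 4, whose structure is `Cc1cc(Br)c2nc(-c3nnc(-c4ccc(N(C)C)cc4)o3)cn2c1`, has not yet been measured. It differs from compound 3 by dimethylamino in place of bromo on an aromatic carbon, and the place of that exchange reads the same, word for word, as the place of the exchange from compound 1 to compound 2, so it is the same change carried onto the second core. Within the data shown here, because the earlier exchange gave a 3.3-fold lower number from compound 1 to compound 2 (0.51 log units; beyond the scatter), the same change is expected to produce a 3.3-fold lower number from compound 3 to compound 4 (0.51 log units; beyond the scatter) in this assay, with the caution that only one prior instance supports it. On that basis compound 4 is estimated at 7500 nM in this assay, with a range from 3500 nM to 16000 nM.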

Compound 4, half-maximal inhibitory concentration: 11200 nM
Estimate against measurement, compound 4: 1.5-fold (0.17 log units) below; the range from low to high includes it.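

In this assay, the exchange of bromo for dimethylamino on the second core gave a 2.2-fold lower number from compound 3 to compound 4 (0.34 log units; beyond the scatter), so the number fell on both cores, and on each the fall lies beyond the scatter. The sizes of the two steps cannot be told apart, so the series gives no sign that the core of compound 1 and the core of compound 3 respond differently to this exchange: the same change on two cores in this assay, a 3.3-fold lower number (0.51 log units; beyond the scatter) from compound 1 to compound 2 and a 2.2-fold lower number (0.34 log units; beyond the scatter) from compound 3 to compound 4, 1.5-fold (0.17 log units) apart, within the scatter of two such steps. Among these compounds, this supports carrying the change between these two cores in this assay, but it rests on only two pairs and does not show that the change would behave the same way on any other core, in any other cell line, or why the number falls at all.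

The compounds shown leave open whether other groups at the same place, such as a primary amine, a morpholine ring, a methoxy group or a carboxylic acid, would lower the number further or fail to lower it. They also leave open whether a longer chain on the nitrogen, in place of the two methyl groups of dimethylamino, would keep the step seen on both cores.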